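The source may hold more compounds than are shown below. What is called first, only, known or untested is meant among the compounds shown, and "the series" means these compounds.

Compound 3 `O=C(NCCCCn1cccn1)c1cccc(C2SCC(=O)N2c2cccnc2)c1` carries a pyridin-3-yl group on the ring nitrogen of the shared core and a four-carbon chain ending in a pyrazole on the amide side. In a functional assay on HOS-TE85 cells (Homo sapiens) for inhibition, read by CCK-8 assay, with a stated time of 72 h (on this read-out lower numbers stand for stronger inhibition and higher numbers for weaker inhibition), compound 3 gives only a limit, > 1000 nM, not a number; this is the limit of > 1000 nM in this assay, at which 1 of the 3 values shown sits. Two measured relatives put the core itself in a clearer light. Compound 1 `O=C(NCCCCc1ccccc1)c1cccc(C2SCC(=O)N2c2cccc(-c3c[nH]nn3)c2)c1`, which carries a phenylbutyl amide and a triazolyl-substituted phenyl on the ring nitrogen, gives 110 nM in this assay. Compound 2 `COc1ccccc1N1C(=O)C(C)SC1c1cccc(C(=O)NCCCCc2ccccc2)c1`, which pairs the same phenylbutyl amide with a 2-methoxyphenyl on the ring nitrogen and a methyl on the core, gives 45.1 nM in this assay. Compound 4 `COc1ccccc1N1C(=O)CSC1c1cccc(C(=O)NCCCCn2cccn2)c1` is not yet measured. It differs from compound 3 in one place (2-methoxyphenyl in place of pyridin-3-yl on an amide-type nitrogen in a ring). Since compound 2 shows that the 2-methoxyphenyl group sits in an active compound, while compound 3 shows the pyridin-3-yl and pyrazolylbutyl pairing reaching only the limit, a step toward stronger inhibition is expected for compound 4, estimated as an at least 2.5-fold lower number from compound 3 to compound 4 (0.39 log units; beyond the scatter). Compound 4 is expected to give about 400 nM in this assay, in a range from 100 nM to 2000 nM.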

Compound 4, half-maximal inhibitory concentration: 91.7 nM
The estimate for compound 4 lay 4.4-fold (0.64 log units) above the measured number, outside the stated range (below it).
By their numbers in this assay, from the lowest: compound 2; then compounds 4 and 1 (each within the scatter of the next). At a limit, above all of these: compound 3.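

In this assay, with the four-carbon chain ending in a pyrazole held the same, the change on the amide-type nitrogen alone brings an at least 10-fold lower number from compound 3 to compound 4 (1.03 log units; beyond the scatter). That chain therefore does not by itself keep a compound at the limit, which compounds 1 and 2, both phenylbutyl amides, could not show. Compound 3 gives a limit and not a number, so this step gives only a minimum size: the limit of > 1000 nM in this assay, at which 1 of the 4 values shown sits.

The change replaces the ring nitrogen of pyridin-3-yl with carbon and adds a methoxy group at once, so a plain phenyl would be needed to separate the two, and an ethoxy or hydroxy group in place of the methoxy would test how far the oxygen substituent can vary. From the compounds shown here alone, how the pyrazole and phenyl chain ends compare with 2-methoxyphenyl held fixed, without the methyl on the core, also remains open.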